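The source may hold more compounds than are shown below. What is called first, only, known or untested is meant among the compounds shown, and "the series" means these compounds.

Measured compounds:
- compound 1 `O=S(=O)(NCC1CCN(CCCc2c[nH]c3ccc(-n4cnnc4)cc23)CC1)c1ccccc1`: 12 nM
- compound 2 `OCCC(NC1CCN(CCCc2c[nH]c3ccc(-n4cnnc4)cc23)CC1)c1ccccc1`: 5.1 nM
- compound 3 `CC(C)=CCN(C)C1CCN(CCCc2c[nH]c3ccc(-n4cnnc4)cc23)CC1`: 1.8 nM

In an assay on CHO cells for agonist activity at 5-hydroxytryptamine receptor 1D (Homo sapiens), read by GTPgammaS binding (a lower number here means that less compound is needed, a higher number that more compound is needed for the effect), compound 1 gives the highest of the three numbers; compound 2 is the nearest to it, compound 3 the furthest. The step from compound 1 to compound 2 was a 2.4-fold lower number from compound 1 to compound 2 (0.37 log units; beyond the scatter), and the step from compound 1 to compound 3 was a 6.7-fold lower number from compound 1 to compound 3 (0.82 log units; beyond the scatter); between the other two the step was a 2.8-fold lower number from compound 2 to compound 3 (0.45 log units; beyond the scatter). Each of these steps lowered the number beyond the scatter, and each of them changes the group on the saturated ring carbon of the shared core.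

Compound 4 `c1ccc2c(c1)CCC2NCC1CCN(CCCc2c[nH]c3ccc(-n4cnnc4)cc23)CC1` is not yet measured. It differs from compound 1 by 2,3-dihydro-1H-inden-1-yl in place of phenylsulfonyl on an amine nitrogen. The change again sits on the outer part of the shared core, at the same end that was varied between compounds 1, 2 and 3, and the (phenylsulfonyl)amino group of compound 1 gives way to a (2,3-dihydro-1H-inden-1-yl)amino group. Both measured steps away from compound 1 lowered the number modestly, and the step to compound 4 is therefore expected to lower it as well, by about a 3.0-fold lower number from compound 1 to compound 4 (0.48 log units; beyond the scatter). For compound 4 in this assay the expected value is 4 nM, with a range from 1.5 nM to 12 nM.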

Compound 4, half-maximal effective concentration: 1.3 nM
The estimate for compound 4 lay 3.1-fold (0.49 log units) above the measured number, and the stated range ends above it.
By their numbers in this assay, from the lowest: compounds 4 and 3 (each within the scatter of the next); then compound 2; then compound 1.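

In this assay, putting 2,3-dihydro-1H-inden-1-yl in place of phenylsulfonyl on the amine nitrogen gave a 9.2-fold lower number from compound 1 to compound 4 (0.97 log units; beyond the scatter), a larger step than any earlier one away from compound 1, and it came from a swap in which both groups have 9 heavy atoms and a six-membered aromatic ring of carbon only, while the hydrogen-bond acceptors go from 2 to 0. The new group also gave a 3.9-fold lower number from compound 2 to compound 4 (0.59 log units; beyond the scatter), beyond the scatter, whereas a 1.4-fold lower number from compound 3 to compound 4 (0.14 log units; within the scatter) lies within it, so two differently built groups at this end of the shared core, ((2,3-dihydro-1H-inden-1-yl)amino)methyl and methyl(3-methylbut-2-en-1-yl)amino, cannot be told apart here. Nothing available explains the size of the step from compound 1 to compound 4.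

The compounds shown do not separate the effect of losing phenylsulfonyl from that of gaining 2,3-dihydro-1H-inden-1-yl, which a plain benzyl or methyl group on the same amine nitrogen could address. They also leave open what the methylene carbon contributes, since a (2,3-dihydro-1H-inden-1-yl)amino group set directly on the saturated ring carbon does not appear among them.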